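Second chloro on the fused core of compound 2

This account rests on a few compounds, and the source may have more. Where it says the series, first, only, none or still open, it means among the compounds named here.

Measured so far:
compound 1, `ClCc1cccc(Cn2cnc3c(Cl)ncnc32)c1`, 4570 nM
compound 2, `ClCc1ccccc1Cn1cnc2ncnc(Cl)c21`, 3460 nM

Both numbers come from a functional assay on TK-10 cells (Homo sapiens) for cytotoxicity, read by sulforhodamine B assay, with a stated time of 48 h; on this read-out higher numbers stand for weaker inhibition of growth and lower numbers for stronger inhibition of growth. Compound 1 and compound 2 differ only in where the chloromethyl group sits on the pendant benzene ring, and their values lie within the usual scatter of each other, so no ordering between them holds. Compound 2 is the reference for the next step.

Compound 3, `ClCc1ccccc1Cn1cnc2nc(Cl)nc(Cl)c21`, carries chloro in place of hydrogen on an aromatic carbon. For the measured compounds named here, no comparable step between measured compounds is available, so the size of the effect is unknown. Going by the values given here, with only two close values to lean on, the working expectation is a change in this assay of no more than the scatter, in either direction.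

Compound 3 is estimated at 3000 nM, with a range from 1200 nM to 8000 nM. That estimate means a step of a 1.2-fold lower number from compound 2 to compound 3 (0.06 log units; within the scatter), expected to stay within the scatter.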

Compound 3, concentration for 50% growth inhibition: 19500 nM
Compound 3: the middle estimate sits 6.5-fold (0.81 log units) below what was measured, outside the stated range (above it).
By their numbers in this assay, from the lowest: compounds 2 and 1 (each within the scatter of the next); then compound 3.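

In this assay, chloro in place of hydrogen on the aromatic carbon between two ring nitrogen atoms gives a 5.6-fold higher number from compound 2 to compound 3 (0.75 log units; beyond the scatter), so this position of the shared core responds to substitution. For the compounds shown here, the earlier pair, which differs only in where the chloromethyl group sits on the pendant benzene ring, gave no ordering, and this is the first step beyond the scatter, running towards weaker inhibition of growth. Nothing available bears on why this single step goes this way.

From the compounds shown here alone, whether the change belongs to chloro in particular stays open: an amine, a methoxy group or a methyl group on the same carbon would separate that from substitution there in general. Also open, going by these compounds, is whether the same step holds with the chloromethyl group placed as in compound 1.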